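Trimming the Benzylic Amine on a Shared Urea Core

The source may hold more compounds than are shown below. What is called first, only, known or untested is meant among the compounds shown, and "the series" means these compounds.

In a functional assay on A549 cells (Homo sapiens) for antiproliferative activity, read by MTT assay, with a stated time of 72 h (a higher number here means a weaker inhibitor, a lower number a stronger inhibitor), compound 1 `COc1ccc(Nc2ncnc3ccc(NC(=O)Nc4ccc(CN5CCN(C)CC5)cc4)cc23)cc1Cl` gives 3570 nM, compound 2 `CN1CCN(Cc2ccc(NC(=O)Nc3ccc4ncnc(Nc5cccc(C(F)(F)F)c5)c4c3)cc2)CC1` gives 1650 nM, and compound 3 `O=C(Nc1ccc(CN2CCCC2)cc1)Nc1ccc2ncnc(Nc3cccc(C(F)(F)F)c3)c2c1` gives 830 nM. The first step gave a 2.2-fold lower number from compound 1 to compound 2 (0.34 log units; beyond the scatter); the second gave a 2.0-fold lower number from compound 2 to compound 3 (0.30 log units; within the scatter). Compound 3 thus carries the lowest number of the three, though its gap to compound 2 lies within the scatter. Compound 4 `CN(C)Cc1ccc(NC(=O)Nc2ccc3ncnc(Nc4cccc(C(F)(F)F)c4)c3c2)cc1` differs from compound 3 by dimethylamino in place of pyrrolidin-1-yl on a saturated chain carbon bound to an aromatic carbon. Within the data shown here, only the step from compound 2 to compound 3 bears on this, being a swap of the amine at the same place, and it stayed within the scatter. In this assay no step beyond the scatter is therefore expected. Compound 4 is estimated at 800 nM, with a range of 350 nM to 1800 nM. This amounts to an expected 1.0-fold lower number from compound 3 to compound 4 (0.02 log units; within the scatter).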

Compound 4, half-maximal inhibitory concentration: 1120 nM
Compound 4: the middle estimate sits 1.4-fold (0.15 log units) below what was measured; measured number inside the range.
By their numbers in this assay, from the lowest: compounds 3, 4 and 2 (each within the scatter of the next); then compound 1.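

In this assay, dimethylamino in place of pyrrolidin-1-yl gives a step that stays within the scatter (a 1.3-fold higher number from compound 3 to compound 4 (0.13 log units; within the scatter)), and so does dimethylamino in place of 4-methylpiperazin-1-yl (a 1.5-fold lower number from compound 2 to compound 4 (0.17 log units; within the scatter)). On this saturated chain carbon, then, an amine without a ring reads the same as the two ring-bearing amines, so the ring itself is not needed to hold the number at this level. No measurement is available that would explain this result. Still open, as far as these compounds go, is whether a morpholine, a primary amine or a carboxylic acid at this place would stay within the scatter of these three compounds.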